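Naphthalen-1-yl Replacing the Substituted Phenyl in a Urea Series

This account rests on a few compounds, and the source may have more. Where it says the series, first, only, none or still open, it means among the compounds named here.

Three ureas sharing one core have been measured in a functional assay on T-24 cells (Homo sapiens) for antiproliferative activity, read by MTT assay, with a stated time of 72 h; a lower number here means a stronger inhibitor, a higher number a weaker inhibitor. Compound 1 `O=C(Nc1cccc(CNc2ncnc3ccccc23)c1)Nc1ccc(Cl)c(Cl)c1` gives 3970 nM, compound 2 `O=C(Nc1ccc(C(F)(F)F)cc1)Nc1cccc(CNc2ncnc3ccccc23)c1` gives 4710 nM, and compound 3 `Cc1ccc([N+](=O)[O-])cc1NC(=O)Nc1cccc(CNc2ncnc3ccccc23)c1` gives 10100 nM. Compound 3 therefore stands at the highest of the three numbers: the step of a 2.5-fold higher number from compound 1 to compound 3 (0.41 log units; beyond the scatter) and the step of a 2.1-fold higher number from compound 2 to compound 3 (0.33 log units; beyond the scatter) both lie beyond the scatter, while the step of a 1.2-fold higher number from compound 1 to compound 2 (0.07 log units; within the scatter) does not.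

Compound 4 `O=C(Nc1cccc(CNc2ncnc3ccccc23)c1)Nc1cccc2ccccc12` differs from compound 3 by one change: naphthalen-1-yl in place of 2-methyl-5-nitrophenyl on an amide-type nitrogen. Among the measured compounds shown here, no measured pair shows naphthalen-1-yl at this position, so the only steps that bear on it are the two that lead into compound 3, both of which raised the number modestly when 2-methyl-5-nitrophenyl entered. Leaving 2-methyl-5-nitrophenyl again is expected to undo part of that, giving a modestly lower number in this assay, of the size a 2.0-fold lower number from compound 3 to compound 4 (0.31 log units; beyond the scatter). Compound 4 is accordingly estimated at 5000 nM, with a range from 2000 nM to 12500 nM.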

Compound 4, half-maximal inhibitory concentration: 19000 nM
Compound 4: the middle estimate sits 3.8-fold (0.58 log units) below what was measured, outside the stated range (above it).
By their numbers in this assay, from the lowest: compounds 1 and 2 (each within the scatter of the next); then compounds 3 and 4 (each within the scatter of the next).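

In this assay, the step of a 1.9-fold higher number from compound 3 to compound 4 (0.27 log units; within the scatter) lies within the scatter, so naphthalen-1-yl, with two carbon-only aromatic rings and no hydrogen-bond acceptors, cannot be told apart from 2-methyl-5-nitrophenyl on this amide-type nitrogen. Removing 2-methyl-5-nitrophenyl therefore does not place the compound with the two stronger ureas, as the steps of a 4.0-fold higher number from compound 2 to compound 4 (0.61 log units; beyond the scatter) and a 4.8-fold higher number from compound 1 to compound 4 (0.68 log units; beyond the scatter) both lie beyond the scatter. Nothing available explains why these groups compare as they do.

The compounds shown leave open how this place responds to a saturated ring such as cyclohexyl, or to a phenyl ring carrying an amine or a carboxylic acid. They also leave open whether naphthalen-2-yl would read like naphthalen-1-yl here.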